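Pyridin-4-yl in place of dichlorophenyl on a triple-bonded carbon

The source may report more compounds than this note shows. Statements on the series, on what has been measured and on what is new or still open speak of the compounds shown alone.

The three measured compounds in an assay for inhibition of Fatty-acid amide hydrolase 1 (Rattus norvegicus) (on this read-out lower numbers stand for stronger inhibition and higher numbers for weaker inhibition), are:
compound 1 `O=C(CCCCC#Cc1ccccn1)c1ncc(-c2ccccn2)o1` with 280 nM
compound 2 `O=C(CCCCC#Cc1cccnc1)c1ncc(-c2ccccn2)o1` with 300 nM
compound 3 `O=C(CCCCC#Cc1cccc(Cl)c1Cl)c1ncc(-c2ccccn2)o1` with 5 nM

Compound 3 stands lowest of the three: a 56-fold lower number from compound 1 to compound 3 (1.75 log units; beyond the scatter) and a 60-fold lower number from compound 2 to compound 3 (1.78 log units; beyond the scatter) both lie far beyond the scatter, whereas a 1.1-fold higher number from compound 1 to compound 2 (0.03 log units; within the scatter) stays within it. Compound 4 `O=C(CCCCC#Cc1ccncc1)c1ncc(-c2ccccn2)o1` differs from compound 3 by pyridin-4-yl in place of 2,3-dichlorophenyl on a triple-bonded carbon. The two large steps just named bear directly on this change, since each of them put 2,3-dichlorophenyl in place of a pyridinyl group and lowered the number strongly. Going back from 2,3-dichlorophenyl to a pyridinyl group is therefore expected to raise the number by a comparably large step, a 60-fold higher number from compound 3 to compound 4 (1.78 log units; beyond the scatter), toward the values of compound 1 and compound 2. Compound 4 is estimated at 300 nM in this assay, with a range from 120 nM to 800 nM.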

Compound 4, inhibition constant: 150 nM
Estimate against measurement, compound 4: 2.0-fold (0.30 log units) above; measured number inside the range.
By their numbers in this assay, from the lowest: compound 3; then compounds 4, 1 and 2 (each within the scatter of the next).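

In this assay, pyridin-4-yl in place of 2,3-dichlorophenyl gives a 30-fold higher number from compound 3 to compound 4 (1.48 log units; beyond the scatter), so all three pyridinyl groups now stand well apart from 2,3-dichlorophenyl on the triple-bonded carbon. The pyridinyl groups themselves cannot be told apart, with a 2.0-fold lower number from compound 2 to compound 4 (0.30 log units; within the scatter) and a 1.9-fold lower number from compound 1 to compound 4 (0.27 log units; within the scatter) both within the scatter. Nothing measured here explains the gap between the pyridinyl groups and 2,3-dichlorophenyl.

On these data alone, it remains open whether that gap belongs to the chlorines or to the all-carbon ring. A plain phenyl or a chlorophenyl group would separate the two.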